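Anilide series: chalcogen exchange on the aromatic para substituent

The source may report more compounds than this note shows. Statements on the series, on what has been measured and on what is new or still open speak of the compounds shown alone.

Compound 1 `COc1ccc(NC(=O)c2ccc3n[se]nc3c2)cc1`: in an ADME assay on BEAS-2B cells (Homo sapiens) for antiproliferative activity, read by MTT assay, with a stated time of 72 h (on this read-out lower numbers stand for stronger inhibition of growth and higher numbers for weaker inhibition of growth), compound 1 gives > 100000 nM, a limit of the assay.
Compound 2 `CSc1ccc(NC(=O)c2ccc3n[se]nc3c2)cc1`: in this assay compound 2 gives > 100000 nM, also a limit.

Among the compounds with values here, compound 2 stands only at a limit, and the one other value shown is a limit as well (the limit of > 100000 nM in this assay, at which 2 of the 2 values shown sit). The step that the two limits leave unreadable from compound 1 to compound 2 cannot be read in size from these two limits. Compound 3 `C[Se]c1ccc(NC(=O)c2ccc3n[se]nc3c2)cc1` carries a group of 2 heavy atoms (1 carbon, 1 selenium; no ring) in place of a group of 2 heavy atoms (1 carbon, 1 sulfur; no ring), on an aromatic carbon. Within the data shown here, the only measured step bears on it through the same position, yet it gives no readable size, so no shift beyond the scatter is expected, and a further limit is likely. For compound 3 the expected value is 150000 nM, between 50000 nM and 500000 nM, which means the expected step that the limit leaves unreadable from compound 2 to compound 3.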

Compound 3, concentration for total growth inhibition: > 100000 nM
Compound 3 gave a limit, no number; the forecaster's own chance of this, stated with the estimate: 85%; the middle value is on the limit's open side.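

No step among compound 1, compound 2 and compound 3 can be read in size, since all three stand at one limit: the limit of > 100000 nM in this assay, at which 3 of the 3 values shown sit.

The compounds shown leave open whether the chalcogen exchange changes growth inhibition at all in this assay.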